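Bromo in Place of Methoxy on Compound 1

The compounds below may be only part of what the source reports. "The series", "measured", "known", "first", "only" and "open" are said of these compounds alone.

Among the measured compounds shown here, in a functional assay on MCF7 cells (Homo sapiens) for inhibition, read by MTT assay, with a stated time of 48 h (on this read-out higher numbers stand for weaker inhibition and lower numbers for stronger inhibition), compound 1 (`COc1ccc(C(=O)C=CNc2cc(-c3ccccc3)nn2-c2ccccc2)cc1`) gives 1290 nM and holds the lowest of the two numbers so far. Compound 2 (`N#Cc1c(-c2ccccc2)nc2c(c(-c3ccccc3)nn2-c2ccccc2)c1-c1ccc(N2CCCCC2)cc1`) gives 27000 nM and the gap between the two lies beyond the usual scatter. Compound 2 is built quite differently, so that gap says little about any single group. Compound 3 (`O=C(C=CNc1cc(-c2ccccc2)nn1-c1ccccc1)c1ccc(Br)cc1`) keeps the core of compound 1 but has bromo in place of methoxy on an aromatic carbon, para to a large group (bromo in place of methoxy on an aromatic carbon). For the measured compounds named here, no measured pair shows this exchange, so the expectation rests only on compound 1 at 1290 nM and on the change itself. The expected step (a 1.2-fold higher number from compound 1 to compound 3 (0.07 log units; within the scatter)) in this assay is small and most likely none beyond the scatter, with no firm direction. For compound 3 the estimate is 1500 nM with an expected range from 500 nM to 4500 nM in repeat measurements.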

Compound 3, half-maximal inhibitory concentration: 21700 nM
The estimate for compound 3 lay 14-fold (1.16 log units) below the measured number; measured number outside the range, above it.
By their numbers in this assay, from the lowest: compound 1; then compounds 3 and 2 (each within the scatter of the next).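

Replacing 4-methoxyphenyl with 4-bromophenyl on the shared core is far from a silent exchange: in this assay it gives a 17-fold higher number from compound 1 to compound 3 (1.23 log units; beyond the scatter) and shows that the number is sensitive to the group on this aromatic carbon, para to a large group. The earlier pair could not show this, since compound 1 and compound 2 differ in more than one place. Why the number rises cannot be told, as no evidence on the cause is at hand.

Going by these compounds, whether other groups on this carbon, such as fluoro, hydroxy or an amine, would stay close to compound 1 or move toward compound 3 remains open. Also open, on these data alone, is whether the same exchange would bring a step of similar size on a different core.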